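Swapping the Amide's Aryl Group for Benzofuran

The compounds below may be only part of what the source reports. "The series", "measured", "known", "first", "only" and "open" are said of these compounds alone.

Measured compounds:
- compound 1, `CN1[C@@H]2c3[nH]c4ccccc4c3C[C@H]1[C@H](C#N)N1[C@@H](CNC(=O)c3ccc(Cl)cc3)c3[nH]c4ccccc4c3C[C@@H]21`: 350 nM
- compound 2, `CCc1ccc(C(=O)NC[C@H]2c3[nH]c4ccccc4c3C[C@H]3[C@H]4c5[nH]c6ccccc6c5C[C@@H]([C@H](C#N)N23)N4C)cc1`: 570 nM

Both compounds were tested in a functional assay on HepG2 cells (Homo sapiens) for cytotoxicity, read by MTT assay, with a stated time of 72 h; a lower number here means a stronger inhibitor, a higher number a weaker inhibitor. Compound 1 gives 350 nM and has the lowest number of the two; compound 2 sits closest to it, and the step of a 1.6-fold higher number from compound 1 to compound 2 (0.21 log units; within the scatter) is within the usual scatter, so the two cannot be told apart with confidence.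

The unmeasured compound 3, `CN1[C@@H]2c3[nH]c4ccccc4c3C[C@H]1[C@H](C#N)N1[C@@H](CNC(=O)c3cc4ccccc4o3)c3[nH]c4ccccc4c3C[C@@H]21`, differs from compound 1 at the aromatic group attached to the amide carbonyl: 1-benzofuran-2-yl in place of 4-chlorophenyl on a carbonyl carbon.

Going by the values given here, the only measured step, from compound 1 to compound 2, replaces one substituent on that same aromatic ring with another and leaves the number essentially unchanged. That step is related but not the same as exchanging the whole ring for a bicyclic one, so it gives only weak guidance. Given that the one known change at this position did nothing beyond the scatter, compound 3 is expected to stay near compound 1, with an estimated step of a 1.3-fold higher number from compound 1 to compound 3 (0.11 log units; within the scatter). For compound 3 the estimate is 450 nM, within a range from 150 nM to 1400 nM.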

Compound 3, half-maximal inhibitory concentration: 280 nM
Compound 3: the middle estimate sits 1.6-fold (0.21 log units) above what was measured; the measured number falls inside the stated range.
By their numbers in this assay, from the lowest: compounds 3, 1 and 2 (each within the scatter of the next, the first and the last beyond it).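

The earlier compounds shown here changed only one substituent on a phenyl ring, whereas compound 3 shows that the whole 4-chlorophenyl group on the carbonyl carbon can be exchanged for 1-benzofuran-2-yl, which has two aromatic rings and a hydrogen-bond acceptor, without a change that can be told from the scatter in this assay (a 1.3-fold lower number from compound 1 to compound 3 (0.10 log units; within the scatter)). Set against the 4-ethylphenyl group, the same benzofuran gives the only step in this set that lies beyond the scatter, though it is modest (a 2.0-fold lower number from compound 2 to compound 3 (0.31 log units; beyond the scatter)). Since compound 1 and compound 2 cannot be separated from each other, this position has so far accepted three different aromatic groups with all values staying close together. Nothing available explains these small differences.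

Going by these compounds, it remains open whether a non-aromatic group such as cyclohexyl, or a chain carrying an amine or a carboxylic acid, would keep the number in this range. A 2-naphthyl group or an indol-2-yl group would also help show whether the ring oxygen of the benzofuran matters here.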